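The source may hold more compounds than are shown below. What is called first, only, known or untested is meant among the compounds shown, and "the series" means these compounds.

Compound 1 `CCCCC#Cc1c[nH]c(=O)[nH]c1=O`: 113000 nM
Compound 2 `O=c1[nH]cc(C#CC2CCCCC2)c(=O)[nH]1`: 62800 nM
Compound 3 `O=c1[nH]c(=O)n([C@@H]2O[C@H](CO)[C@@H](O)[C@H]2O)cc1C#CC1CC1`: 24200 nM

Three compounds share a core and carry a triple-bonded substituent on it, and all three have been tested in an ADME assay on MRC5 cells (Homo sapiens) for cytotoxicity, read by MTT assay; on this read-out lower numbers stand for higher toxicity in this test and higher numbers for lower toxicity in this test. Compound 1 gives 113000 nM, the highest of the three numbers. Compound 2 gives 62800 nM, and the two numbers for compound 1 and compound 2 fall within the usual scatter of each other, so nothing separates them. Compound 3 gives 24200 nM, which is a lower number than that of compound 1 and lies beyond the scatter.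

Compound 4 `CCC#Cc1c[nH]c(=O)[nH]c1=O` has not been tested in this assay. It differs from compound 1 in one place: hydrogen in place of ethyl on a saturated chain carbon, two bonds along the chain from a triple-bonded carbon. Among the compounds with values here, no pair of measured compounds shows this kind of change, so there is no measured step to lean on. A small upward step is expected, a 1.3-fold higher number from compound 1 to compound 4 (0.12 log units; within the scatter), one that may well sit within the scatter. Compound 4 is therefore estimated to give 150000 nM, in a range from 70000 nM to 350000 nM.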

Compound 4, half-maximal cytotoxic concentration: 120000 nM
Compound 4: middle estimate off by 1.3-fold (0.10 log units), on the high side; low and high end bracket the measured number.
By their numbers in this assay, from the lowest: compound 3; then compounds 2, 1 and 4 (each within the scatter of the next).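

In this assay, hydrogen in place of ethyl on a saturated chain carbon, two bonds along the chain from a triple-bonded carbon, gives a 1.1-fold higher number from compound 1 to compound 4 (0.03 log units; within the scatter) and so lies within the scatter. Within the data shown here, this is the first measured step at this place, and it shows that nothing separates the two compounds in this test. Read one bond further out, the same difference is butyl to ethyl, so at this place these two chain lengths cannot be told apart; nothing measured here offers an explanation for this.

The compounds shown leave open whether a chain longer than butyl would stay within the scatter of compound 1. They also leave open whether an amine or a carboxylic acid at this place would give a different number.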